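A chloro substituent on the pyridinyl ring of compound 1

A few compounds are considered here, and "the series" means these few. Any claim that something is new, unique, unknown or untested is made for them only; others in the source may bear on it.

Compound 1 `O=C(CN1CCN(c2ccccn2)CC1)Nc1cccnc1` gives 1080 nM in a functional assay on cells for agonist activity at D(4) dopamine receptor (Homo sapiens), read by TR-FRET and cAMP accumulation, with a stated time of 30 min (a higher number here means that more compound is needed for the effect, a lower number that less compound is needed), the highest of the two numbers recorded. Compound 3 `Cc1cccc(NC(=O)CN2CCN(c3ccccn3)CC2)c1` gives 3.6 nM in this assay, and the step that puts 3-methylphenyl in place of pyridin-3-yl on an amide-type nitrogen is a 300-fold lower number from compound 1 to compound 3 (2.48 log units; beyond the scatter). Compound 2 `O=C(CN1CCN(c2ccccn2)CC1)Nc1cncnc1` was reported as "not active" (no number reported) in this assay, without a number. Compound 4 `O=C(CN1CCN(c2ccc(Cl)cn2)CC1)Nc1cccnc1` differs from compound 1 by chloro in place of hydrogen on an aromatic carbon, that is pyridin-2-yl to 5-chloropyridin-2-yl. Going by the values given here, no measured step touches this ring; the only measured step changes the aryl on the amide-type nitrogen, so it gives no guidance here. Compound 4 is therefore expected to show a 1.4-fold lower number from compound 1 to compound 4 (0.13 log units; within the scatter), a step not beyond the scatter, with an estimate of 800 nM ranging from 200 nM to 4000 nM.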

Compound 4, half-maximal effective concentration: "not active" (no number reported)
The entry for compound 4 holds no number; no gap can be computed for the estimate.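

Compound 4 is recorded as "not active" without a number, so in this assay no step can be read from compound 1 to it, and no evidence bears on this result. The compounds shown leave open what 5-chloropyridin-2-yl does when the 3-methylphenyl of compound 3 is present.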